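From 3-bromophenyl to 3-nitrophenyl: working notes

This account rests on a few compounds, and the source may have more. Where it says the series, first, only, none or still open, it means among the compounds named here.

Three compounds share one core and differ in a single group on an aromatic ring: compound 1 (`CCOC(=O)c1c(-c2cccc(Oc3ccccc3)c2)[nH]c2cc(OC)ccc2c1=O`), compound 2 (`CCOC(=O)c1c(-c2cccc(C(F)(F)F)c2)[nH]c2cc(OC)ccc2c1=O`) and compound 3 (`CCOC(=O)c1c(-c2cccc(Br)c2)[nH]c2cc(OC)ccc2c1=O`). In an ADME assay on HepG2 cells (Homo sapiens) for cytotoxicity, read by luminescence, with a stated time of 72 h (on this read-out lower numbers stand for an effect already at smaller amounts and higher numbers for an effect only at larger amounts of compound), compound 1 gives > 21500 nM as a limit of the assay. Compound 2 gives > 21500 nM as a limit too. Compound 3 gives > 21500 nM and this is also a limit. Compound 3 therefore has no number of its own and stands with the other two (the limit of > 21500 nM in this assay, at which 3 of the 3 values shown sit).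

Compound 4 (`CCOC(=O)c1c(-c2cccc([N+](=O)[O-])c2)[nH]c2cc(OC)ccc2c1=O`) carries nitro in place of bromo on an aromatic carbon, meta to a large group (nitro in place of bromo on an aromatic carbon).

Three measured steps exchange the group at this place: trifluoromethyl for phenoxy (a step that the two limits leave unreadable from compound 1 to compound 2), bromo for phenoxy (a step that the two limits leave unreadable from compound 1 to compound 3) and bromo for trifluoromethyl (a step that the two limits leave unreadable from compound 2 to compound 3). None of them has a readable size, and none involves nitro. In this assay no step beyond the scatter is expected, in either direction, and the reason is that compound 3 sits at the limit shared by all measured compounds (the limit of > 21500 nM in this assay, at which 3 of the 3 values shown sit). The expected step is a step that the limit leaves unreadable from compound 3 to compound 4 and it remains an estimate. Compound 4 is estimated at 25000 nM with an expected range from 12000 nM to 50000 nM and will probably be reported as a limit.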

Compound 4, half-maximal effective concentration: > 21500 nM
Compound 4 gave a limit, no number; the forecaster's own chance of this, stated with the estimate: 85%; the middle value is on the limit's open side.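

The steps from compound 1, compound 2 and compound 3 to compound 4 cannot be read in this assay, and none has a size: the limit of > 21500 nM in this assay, at which 4 of the 4 values shown sit.

The compounds shown leave open whether any group at this place on the shared core gives a number of its own in this assay, and how these four compounds would order.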